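A few compounds are considered here, and "the series" means these few. Any claim that something is new, unique, unknown or untested is made for them only; others in the source may bear on it.

In a functional assay on HeLa cells (Homo sapiens) for inhibition, read by sulforhodamine B assay (a lower number here means a stronger inhibitor, a higher number a weaker inhibitor), three compounds with a shared core have been measured, and they differ only in the group on an amine nitrogen. Compound 1 `O=C1C=C(Nc2ccccc2F)C(=O)c2c1nc1n2[C@H]2OC[C@@H](O)[C@H]2OC1` gives 5120 nM. Compound 2 `O=C1C=C(Nc2cccc(F)c2)C(=O)c2c1nc1n2[C@H]2OC[C@@H](O)[C@H]2OC1` gives 6440 nM, and the two cannot be told apart, with a 1.3-fold higher number from compound 1 to compound 2 (0.10 log units; within the scatter). Compound 3 `O=C1C=C(NC2CCCC2)C(=O)c2c1nc1n2[C@H]2OC[C@@H](O)[C@H]2OC1`, which carries cyclopentyl, reads > 16000 nM, and this is a limit of the assay, not a number. From the compounds shown here alone, it is the only one of the three at that limit, so its true value is unknown.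

Compound 4 `COc1ccccc1NC1=CC(=O)c2nc3n(c2C1=O)[C@H]1OC[C@@H](O)[C@H]1OC3` differs from compound 3 as follows: 2-methoxyphenyl in place of cyclopentyl on an amine nitrogen. In short, 2-methoxyphenyl stands in place of cyclopentyl on an amine nitrogen.

Among the compounds with values here, two measured steps bear on this change, an at least 3.1-fold higher number from compound 1 to compound 3 (0.49 log units; beyond the scatter) and an at least 2.4-fold higher number from compound 2 to compound 3 (0.39 log units; beyond the scatter). Both run from a fluorophenyl group to cyclopentyl, the opposite way, so a return to a six-membered aromatic ring is expected to lower the number by a modest amount. The expected change is an at least 2.6-fold lower number from compound 3 to compound 4 (0.42 log units; beyond the scatter). For compound 4 the estimate is 6000 nM, with an expected range from 2500 nM to 15000 nM.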

Compound 4, half-maximal inhibitory concentration: 2950 nM
Compound 4: the middle estimate sits 2.0-fold (0.31 log units) above what was measured; the measured number falls inside the stated range.
By their numbers in this assay, from the lowest: compounds 4, 1 and 2 (each within the scatter of the next, the first and the last beyond it). At a limit, above all of these: compound 3.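

Putting 2-methoxyphenyl on the amine nitrogen in place of cyclopentyl gives an at least 5.4-fold lower number from compound 3 to compound 4 (0.73 log units; beyond the scatter) in this assay, so the fall from the cyclopentyl compound is not limited to the two fluorophenyl groups. Among the aromatic groups, the change from 3-fluorophenyl gives a 2.2-fold lower number from compound 2 to compound 4 (0.34 log units; beyond the scatter), a modest step, whereas methoxy in place of fluoro on an aromatic carbon gives a 1.7-fold lower number from compound 1 to compound 4 (0.24 log units; within the scatter), so compound 1 and compound 4 cannot be told apart. The step from cyclopentyl has only a lower bound on its size, since compound 3 sits at a limit and not at a number: the limit of > 16000 nM in this assay, at which 1 of the 4 values shown sits.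

From the compounds shown here alone, how a plain phenyl, a pyridine ring or an open alkyl chain on this nitrogen would read remains open. All these values come from one cell line, so whether the order holds in other cells is also unknown.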